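Swapping an Ester for an Amide on a Shared Core

The source may hold more compounds than are shown below. What is called first, only, known or untested is meant among the compounds shown, and "the series" means these compounds.

Compound 1 `Nc1nc2ccnc(-c3cccc(Br)c3)n2n1` carries a bromine on its phenyl ring, and in a functional assay (Homo sapiens) (on this read-out higher numbers stand for weaker inhibition and lower numbers for stronger inhibition), compound 1 gives 3700 nM; 3700 nM (2 entries). Going by the values given here, compound 2 `CCOC(=O)c1cccc(-c2nccc3nc(N)nn23)c1` keeps the same core but bears an ethoxycarbonyl group instead; in this assay compound 2 gives 11500 nM, the only number so far recorded for it, alongside one further entry without a single number. Among the compounds with values here, no directly computed step links compound 1 and compound 2, so their two values are simply set side by side.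

Compound 3 `CN(C)C(=O)c1cccc(-c2nccc3nc(N)nn23)c1` is the next compound in line, differing from compound 2 in one place: dimethylamino in place of ethoxy on a carbonyl carbon. Within the data shown here, no measured pair shows what such a swap does on this core, so the expectation for compound 3 rests on the single value of compound 2 alone. The step from ester to amide is expected to be small, at most a modest shift toward stronger inhibition and likely within the usual scatter, a 1.4-fold lower number from compound 2 to compound 3 (0.16 log units; within the scatter). Compound 3 is therefore expected to give roughly 8000 nM in this assay, with a plausible range from 3000 nM to 25000 nM.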

Compound 3, half-maximal inhibitory concentration: 3500 nM
Beside the measured number, compound 3's estimate is 2.3-fold (0.36 log units) above it, and the stated range covers the measured number.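

Going by these compounds alone, this is the first measured step on the shared core, and it shows that the group on the carbonyl carbon can move the result in this assay: a 3.3-fold lower number from compound 2 to compound 3 (0.52 log units; beyond the scatter), a change larger than the usual scatter between repeated measurements. The change is also a tight one, as ethoxy and dimethylamino match in heavy-atom count and neither has a ring or a net charge, yet the atom joined to the carbonyl carbon goes from oxygen to nitrogen and the number still falls. Nothing available here explains the stronger inhibition of compound 3, so this step records an effect and not its cause.

A single step cannot separate the part played by the nitrogen from the part played by its two methyl groups, and an unsubstituted amide, a methylamide or a carboxylic acid on the same carbonyl carbon would help to tell them apart. From the compounds shown here alone, whether a ring amide such as a pyrrolidine amide, or a longer chain on the nitrogen, would continue the trend or reverse it also remains open.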